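Cyclohexyl for tert-butyl on the chain amine of compound 3

A few compounds are considered here, and "the series" means these few. Any claim that something is new, unique, unknown or untested is made for them only; others in the source may bear on it.

Of the compounds shown here, three have been measured in a functional assay on HEK293 cells for agonist activity at G-protein coupled receptor 39 (Homo sapiens), read by inositol phosphate accumulation; a higher number here means that more compound is needed for the effect, a lower number that less compound is needed. Compound 1 `COCCNc1nc(NCC2CC2)cc(-c2ccccn2)n1` gives 2200 nM, compound 2 `Cc1nc(NCc2ccc(Cl)cc2)cc(-c2ccccn2)n1` gives 81 nM, and compound 3 `CNc1nc(NCC(C)(C)C)cc(-c2ccccn2)n1` gives 73 nM. Compound 3 carries the lowest of the three numbers; compound 2 stands within the scatter of it, while compound 1 lies beyond the scatter at the high end. Compound 4 `CNc1nc(NCC2CCCCC2)cc(-c2ccccn2)n1` is not yet measured. It differs from compound 3 in one place: cyclohexyl in place of tert-butyl on a saturated chain carbon bound to a nitrogen on an aromatic ring. Within the data shown here, no measured pair isolates this change. Compound 1, with its far higher value, differs from compound 3 in more than one place, so it does not speak to this step alone. The step is expected to be small, within or just beyond the scatter, and is estimated as a 1.5-fold higher number from compound 3 to compound 4 (0.18 log units; within the scatter). For compound 4 the estimate in this assay is 110 nM, expected to fall between 30 nM and 400 nM.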

Compound 4, half-maximal effective concentration: 11 nM
Beside the measured number, compound 4's estimate is 10-fold (1.00 log units) above it; the measured number lies below the stated range.
By their numbers in this assay, from the lowest: compound 4; then compounds 3 and 2 (each within the scatter of the next); then compound 1.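

In this assay, among these compounds, cyclohexyl in place of tert-butyl on a saturated chain carbon bound to a nitrogen on an aromatic ring gives a 6.6-fold lower number from compound 3 to compound 4 (0.82 log units; beyond the scatter), the first isolated step. This place therefore accepts the larger carbon ring and responds to the change by more than the scatter. Nothing measured here accounts for the step.

From the compounds shown here alone, whether the ring itself or only the added carbon carries the step stays open; cyclopentyl, phenyl or a longer open chain would separate these. Also open, going by these compounds, is how tetrahydropyranyl or piperidinyl would read at this place.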